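The compounds below may be only part of what the source reports. "The series", "measured", "known", "first", "only" and "open" are said of these compounds alone.

Measured compounds:
Compound 1, `CN(C)CCC(OC(=O)c1ccc(C(F)(F)F)cc1)c1ccc(Cl)cc1`, 47%
Compound 2, `Cc1ccccc1NC(=O)OC(CCN(C)C)c1ccc(Cl)cc1`, 176%
Compound 3, `COc1ccc(NC(=O)OC(CCN(C)C)c2ccc(Cl)cc2)cc1`, 170%

In an assay on NIH3T3 cells with Urotensin-2 receptor (Homo sapiens) as the target (on this read-out lower numbers stand for smaller maximal responses and higher numbers for larger maximal responses), compound 3 stands second highest of the three numbers. Its nearest neighbour is compound 2, with 176%, within the scatter of compound 3, while compound 1, with 47%, lies far below it, beyond the scatter. The unmeasured compound 4, `CN(C)CCC(OC(=O)Nc1ccc(-c2ccccc2)cc1)c1ccc(Cl)cc1`, differs from compound 3 in one place: phenyl in place of methoxy on an aromatic carbon.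

Within the data shown here, only one measured step exists, and it bears on this change only loosely: a number 6 percentage points lower from compound 2 to compound 3 (within the scatter). That step swaps one substituent on the aromatic ring attached to the amide-type nitrogen for another and leaves the number essentially unchanged. Among the measured compounds shown here, the change to compound 4 is of the same kind, a substituent exchange on that ring, but a phenyl in place of a methoxy is a larger change than either of those, and no measured pair tests it. The step of a number 15 percentage points lower from compound 3 to compound 4 (beyond the scatter) is therefore expected to stay small, within or near the scatter. Compound 4 is expected to give 155%, in a range from 105% to 200%.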

Compound 4, largest response reached (reported as efficacy), in percent of the reference or control that the assay uses: 58%
Estimate against measurement, compound 4: 97 percentage points above; the measured number lies below the stated range.
By their numbers in this assay, from the lowest: compound 1; then compound 4; then compounds 3 and 2 (each within the scatter of the next).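

In this assay, the exchange of methoxy for phenyl on the aromatic carbon para to a large group gives a number 112 percentage points lower from compound 3 to compound 4 (beyond the scatter) and so shows that this place on the ring does not accept every substituent alike. Among these compounds, the earlier step, a number 6 percentage points lower from compound 2 to compound 3 (within the scatter), had left the number within the scatter and showed only that one small group could stand in for another on this ring, whereas the entering phenyl brings a second aromatic ring and six heavy atoms where methoxy has two. Nothing available explains this fall.

From the compounds shown here alone, whether the fall needs an aromatic ring remains open, since a cyclohexyl ring or a longer chain such as butyl at this place might or might not behave like phenyl. Also open, going by these compounds, is how an amine or a carboxylic acid on the added phenyl would change the number.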